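The compounds below may be only part of what the source reports. "The series", "measured", "known", "first", "only" and "open" are said of these compounds alone.

Compound 1 `CC1(C)C=C(n2ccccc2=O)c2ccccc2O1` gives 5.43 in a functional assay (aorta) with Rattus norvegicus as the target; a higher number here means a more potent compound, by a factor of ten per unit of this negative logarithm, a lower number a less potent compound. Compound 2 `COc1ccc2c(c1)C(n1ccccc1=O)=CC(C)(C)O2` gives 6.55. Compound 3 `CC1(C)C=C(n2ccccc2=O)c2cc(C(=O)c3ccc(O)cc3)ccc2O1` gives 6.65.

Compound 3 holds the highest of the three numbers; compound 2 sits a number 0.10 log units higher from compound 2 to compound 3 (within the scatter), and compound 1 sits a number 1.22 log units higher from compound 1 to compound 3 (beyond the scatter). The next compound is compound 4 `CC1(C)C=C(n2ccccc2=O)c2cc(C(=O)c3c(F)cccc3F)ccc2O1`, which is yet to be measured. The change from compound 3 to compound 4 is 2,6-difluorophenyl in place of 4-hydroxyphenyl on a carbonyl carbon. Among the compounds with values here, no measured step matches this exchange on the carbonyl carbon. The steps that come closest are the substitutions on the aromatic carbon of the shared core, where a number 1.12 log units higher from compound 1 to compound 2 (beyond the scatter) and a number 1.22 log units higher from compound 1 to compound 3 (beyond the scatter) were both large and upward, while a number 0.10 log units higher from compound 2 to compound 3 (within the scatter) was within the scatter, so two quite different groups at that position gave near-identical numbers. On that reading the group attached to the carbonyl appears tolerant of variation, and the expected step of a number 0.25 log units lower from compound 3 to compound 4 (within the scatter) for compound 4 is small. Compound 4 is therefore estimated at 6.4, with a range from 5.7 to 7.1.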

Compound 4, logarithm of the reciprocal of the active concentration, log(1/C): 6.97
Estimate against measurement, compound 4: 0.57 log units below, and the stated range covers the measured number.
By their numbers in this assay, from the lowest: compound 1; then compounds 2 and 3 (each within the scatter of the next); then compound 4.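

In this assay, 2,6-difluorophenyl in place of 4-hydroxyphenyl on the carbonyl carbon gives a number 0.32 log units higher from compound 3 to compound 4 (beyond the scatter), the first step shown that changes the group on that carbonyl. The number at this position therefore responds to the group carried there, and the exchange does not depend on keeping a hydrogen-bond donor or acceptor in that group, as the entering group has 0 of each. Nothing shown gives a measured reason for this step.

The exchange removes the hydroxyl and adds two fluorines at once, so the compounds shown cannot assign the step to either change alone. From the compounds shown here alone, how an unsubstituted phenyl, a cyclohexyl or a phenyl bearing an amine would behave on the same carbonyl carbon remains open.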